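A Chloro for Methoxy on the Sulfonyl Aryl Group

The source may report more compounds than this note shows. Statements on the series, on what has been measured and on what is new or still open speak of the compounds shown alone.

Compound 1 `N#C/C(=C\c1ccccc1OS(=O)(=O)c1ccc(Cl)cc1)C(=O)Nc1nnc(Cc2cccc3ccccc23)s1` gives 15%
Compound 2 `Cc1ccc(S(=O)(=O)Oc2ccccc2/C=C(\C#N)C(=O)Nc2nnc(Cc3ccc(F)cc3)s2)cc1` gives "not active" (no number reported)
Compound 3 `COc1ccc(S(=O)(=O)Oc2ccccc2/C=C(\C#N)C(=O)Nc2nnc(Cc3ccc(F)cc3)s2)cc1` gives 100%

These three compounds were examined in a functional assay on HL-60 cells (Homo sapiens) for inhibition, read by CCK-8 assay, with a stated time of 48 h, tested at 20 uM (a lower number here means less inhibition of growth, a higher number more inhibition of growth at the concentration tested), where compound 3 holds the higher of the two numbers, beyond the scatter from compound 1. Compound 2 was reported without a number.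

The next compound to be measured is compound 4 `N#C/C(=C\c1ccccc1OS(=O)(=O)c1ccc(Cl)cc1)C(=O)Nc1nnc(Cc2ccc(F)cc2)s1`. It departs from compound 3 in a single place, with chloro in place of methoxy on an aromatic carbon, para to a large group (chloro in place of methoxy on an aromatic carbon). The same difference reads as 4-methoxyphenyl to 4-chlorophenyl.

Among the compounds with values here, no measured pair isolates this change, so the expectation rests on thin evidence. The 4-chlorophenyl group that enters also appears in compound 1, which reaches only 15% in this assay, and this points to a loss. Compound 2, at "not active" (no number reported), shows that activity is not assured among these compounds. The expected change, a number 60 percentage points lower from compound 3 to compound 4 (beyond the scatter), is a fall beyond the scatter, though its size is highly uncertain. For compound 4 the estimated growth inhibition is 40% (5% to 95%).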

Compound 4, percent growth inhibition at one concentration: 20%
Estimate against measurement, compound 4: 20 percentage points above, within the range that was stated.
By their numbers in this assay, from the lowest: compounds 1 and 4 (each within the scatter of the next); then compound 3.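

In this assay, within the data shown here, the step of a number 80 percentage points lower from compound 3 to compound 4 (beyond the scatter) is the first measured pair to isolate the group on the sulfonyl aryl ring, and it shows that this single exchange, 4-methoxyphenyl to 4-chlorophenyl, is enough to produce a large fall while the 4-fluorophenyl end and the rest of the molecule stay the same. The step of a number 5 percentage points higher from compound 1 to compound 4 (within the scatter) adds that, with the 4-chlorophenyl group held in place, 4-fluorophenyl in place of naphthalen-1-yl on the saturated chain carbon gives no change beyond the scatter, so the low reading of compound 1 is not confined to its naphthalen-1-yl group. Nothing available here explains why the exchange at this position has so large an effect.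

Steps involving compound 2 cannot be read, as it carries no number, so the compounds shown give only one numerical comparison at this position. On these data alone, it remains open whether the strong inhibition seen with compound 3 is particular to methoxy or would also appear with an ethoxy, a hydroxy or a dimethylamino group on the same aromatic carbon.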